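The compounds below may be only part of what the source reports. "The series", "measured", "known", "first", "only" and "open" are said of these compounds alone.

Measured in a physicochemical assay for solubility, read by HPLC, in phosphate buffer, at pH 6.5; on this read-out lower numbers stand for lower solubility and higher numbers for higher solubility:
- compound 1 `COC(=O)C1=C(CN2CCNCC2)NC(c2nccs2)=NC1(C)c1ccc(F)cc1`: 250 ug/mL
- compound 2 `COC(=O)C1=C(CN2CCC(O)CC2)NC(c2nccs2)=NC1(C)c1ccc(F)cc1`: 593 ug/mL
- compound 3 `COC(=O)C1=C(CN2CCCS2(=O)=O)NC(c2nccs2)=NC1(C)c1ccc(F)cc1`: 125 ug/mL

Compound 3 stands at the low end of these numbers, with a 2.0-fold lower number from compound 1 to compound 3 (0.30 log units; within the scatter) and a 4.7-fold lower number from compound 2 to compound 3 (0.68 log units; beyond the scatter). Compound 4 `COC(=O)C1=C(COCC(F)(F)F)NC(c2nccs2)=NC1(C)c1ccc(F)cc1` is still unmeasured and differs from it by a group of 6 heavy atoms (2 carbon, 1 oxygen, 3 fluorine; no ring) in place of a group of 7 heavy atoms (3 carbon, 1 nitrogen, 2 oxygen, 1 sulfur; one five-membered non-aromatic ring with 2 hetero atoms), on a saturated chain carbon bound to a double-bonded ring carbon. The measured steps all concern this same place, and the largest are modest: a 2.4-fold higher number from compound 1 to compound 2 (0.38 log units; beyond the scatter), alongside the step from compound 2 already given. Among the compounds with values here, none of them introduces an open chain, so they offer no direct precedent. A modest fall is expected in this assay, estimated as a 2.8-fold lower number from compound 3 to compound 4 (0.44 log units; beyond the scatter). Compound 4 is estimated at 45 ug/mL, within an expected range of 12 ug/mL to 150 ug/mL.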

Compound 4, solubility: 19 ug/mL
Beside the measured number, compound 4's estimate is 2.4-fold (0.37 log units) above it, and the stated range covers the measured number.
By their numbers in this assay, from the lowest: compound 4; then compounds 3 and 1 (each within the scatter of the next); then compound 2.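

Within the data shown here, at this saturated chain carbon, 2,2,2-trifluoroethoxy is the only group without a ring, and in this assay it gives the lowest number of the series, with a 6.6-fold lower number from compound 3 to compound 4 (0.82 log units; beyond the scatter) and a 13-fold lower number from compound 1 to compound 4 (1.12 log units; beyond the scatter) and a 31-fold lower number from compound 2 to compound 4 (1.49 log units; beyond the scatter). The last two steps are large, so the numbers at this position span more than the ring-bearing groups alone showed. Nothing measured here explains the fall.

On these data alone, whether it follows from the fluorine atoms, the ether oxygen or the loss of a ring remains open. An ethoxy group, a longer chain or an open-chain amine such as dimethylamino on the same carbon would help separate these.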